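The source may hold more compounds than are shown below. What is called first, only, known or untested is meant among the compounds shown, and "the series" means these compounds.

Measured compounds:
compound 1 `COC(=O)c1c(Nc2ccccc2)sc(C(=O)c2ccc(OC)cc2)c1C` – in a functional assay, with a stated time of 150 min, tested at 15 ug/mL (a lower number here means a weaker effect, a higher number a stronger effect of the compound at the concentration tested), compound 1 gives 28.6%
compound 2 `COC(=O)c1c(Nc2ccc(C)cc2)sc(C(=O)c2ccc(OC)cc2)c1C` – in this assay compound 2 gives "not active" (no number reported)

Compound 2 stands without a number in this assay; only the "not active" report is known, so its position against compound 1 cannot be measured. Compound 3 `COC(=O)c1c(Nc2ccc(Cl)cc2)sc(C(=O)c2ccc(OC)cc2)c1C` differs from compound 2 by chloro in place of methyl on an aromatic carbon. Within the data shown here, no measured step exists for this change. In this assay a step from compound 2 to compound 3 within the scatter, or a modest rise at most, is expected. Compound 3 is estimated at 15%, with a range from 0% to 35%.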

Compound 3, a percentage reported as activity, at one concentration (the size of the read-out at that concentration, not a potency): "not active" (no number reported)
Compound 3: no number reported, and the estimate cannot be compared.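

In this assay compound 2 and compound 3 are both reported as "not active" without a number, so no step can be read between them. No further data bear on this result. The compounds shown leave open whether methyl and chloro at this place differ at all.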